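Methoxy for phenoxy on a shared quinone-like core

The source may hold more compounds than are shown below. What is called first, only, known or untested is meant among the compounds shown, and "the series" means these compounds.

Measured so far:
Compound 1, `COC(=O)c1ccc(NC2=CC(=O)c3ncncc3C2=O)cc1`: 5800 nM
Compound 2, `CC(=O)c1cccc(NC2=CC(=O)c3ncncc3C2=O)c1`: 5200 nM
Compound 3, `O=C1C(Nc2ccc(Oc3ccccc3)cc2)=CC(=O)c2ncncc21`: 3600 nM

All three were tested in a functional assay on BXPC-3 cells (Homo sapiens) for cytotoxicity, read by MTT assay, with a stated time of 72 h; a higher number here means a weaker inhibitor, a lower number a stronger inhibitor. Among the measured compounds shown here, compound 3 gives the lowest of the three numbers, but the single measured step, a 1.6-fold lower number from compound 1 to compound 3 (0.21 log units; within the scatter), and the small gap to the value of compound 2 both fall inside the usual scatter, so no compound can be called stronger than another.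

Compound 4, `COc1ccc(NC2=CC(=O)c3ncncc3C2=O)cc1`, is not yet measured. It differs from compound 3 by methyl in place of phenyl on an oxygen on an aromatic ring, the same difference read one bond further out being phenoxy to methoxy. For the measured compounds named here, no measured step touches the oxygen-bound group itself; the only step on this ring, from methoxycarbonyl to phenoxy, stayed within the scatter. A small oxygen-bound group is therefore expected to sit near the compounds with small groups, compound 1 and compound 2, and the expected step of a 1.4-fold higher number from compound 3 to compound 4 (0.14 log units; within the scatter) is not expected to exceed the scatter. Compound 4 is estimated at 5000 nM, in the range 2000 nM to 12000 nM.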

Compound 4, half-maximal inhibitory concentration: 1700 nM
Beside the measured number, compound 4's estimate is 2.9-fold (0.47 log units) above it, and the stated range ends above it.
By their numbers in this assay, from the lowest: compound 4; then compounds 3, 2 and 1 (each within the scatter of the next).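

In this assay, among the compounds shown here, the change on the oxygen gives a 2.1-fold lower number from compound 3 to compound 4 (0.33 log units; beyond the scatter), the first step to lie beyond the scatter. It shows that the group on this oxygen can shift the reading, and that here methyl, with its single carbon, goes with the lower number, not the six-carbon phenyl. The second step, a 3.4-fold lower number from compound 1 to compound 4 (0.53 log units; beyond the scatter), is also beyond the scatter, so methoxy can be told apart from methoxycarbonyl on this aromatic carbon, while phenoxy could not; nothing at hand explains either result.

Still open, on these data alone, is whether an ethoxy group or a longer chain on the oxygen would keep the lower number or lose it. As far as these compounds go, it is equally open how a hydroxyl group or an amine would read on the same aromatic carbon.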